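The source may report more compounds than this note shows. Statements on the series, on what has been measured and on what is new or still open speak of the compounds shown alone.

In an ADME assay on L02 cells (Homo sapiens) for cytotoxicity, read by MTT assay, with a stated time of 24 h (on this read-out higher numbers stand for weaker inhibition and lower numbers for stronger inhibition), compound 1 `O=C1/C(=C/c2cccnc2)CN(S(=O)(=O)c2ccc(C(F)(F)F)cc2)C/C1=C\c1ccccc1F` gives 11300 nM and compound 3 `O=C1/C(=C/c2ccncc2)CN(S(=O)(=O)c2ccc(C(F)(F)F)cc2)C/C1=C\c1ccccc1F` gives 18600 nM. The two stand level, with a step of a 1.6-fold higher number from compound 1 to compound 3 (0.22 log units; within the scatter), made by pyridin-4-yl replacing pyridin-3-yl. Compound 2 `N#Cc1ccc(S(=O)(=O)N2C/C(=C\c3cccnc3)C(=O)/C(=C/c3ccccc3F)C2)cc1` reports only a limit, > 20000 nM. Its step, with cyano replacing trifluoromethyl, is an at least 1.7-fold higher number from compound 1 to compound 2 (0.24 log units; that floor lies within the scatter).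

Compound 4 `O=C1/C(=C/c2cccnc2)CN(S(=O)(=O)c2ccc(C(F)(F)F)cc2)C/C1=C\c1ccccc1C(F)(F)F` keeps the core of compound 1 but carries a different group: trifluoromethyl in place of fluoro on an aromatic carbon. This is 2-fluorophenyl becoming 2-(trifluoromethyl)phenyl. Neither measured step touches this place, so they offer only indirect guidance: the edits elsewhere on compound 1 gave a 1.6-fold higher number from compound 1 to compound 3 (0.22 log units; within the scatter) and an at least 1.7-fold higher number from compound 1 to compound 2 (0.24 log units; that floor lies within the scatter). The step expected here is a 1.0-fold lower number from compound 1 to compound 4 (0.01 log units; within the scatter), so none beyond the scatter. The estimate for compound 4 is 11000 nM, with an expected range of 5000 nM to 20000 nM.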

Compound 4, half-maximal inhibitory concentration: 14300 nM
The estimate for compound 4 lay 1.3-fold (0.11 log units) below the measured number; the range from low to high includes it.
By their numbers in this assay, from the lowest: compounds 1, 4 and 3 (each within the scatter of the next). At a limit, above all of these: compound 2.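

Trifluoromethyl in place of fluoro, 4 heavy atoms for 1, is the first change shown on this aromatic ring, and in this assay it gives a 1.3-fold higher number from compound 1 to compound 4 (0.10 log units; within the scatter) with no shift that stands out from the scatter. On this read-out, the two groups cannot be told apart at this position. Nothing measured here offers a cause for this result. Only this one change is shown at the position, so whether an amine or a carboxylic acid there would move the number beyond the scatter remains open. Also open, going by these compounds, is whether the same change would behave alike on compound 3.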